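Swapping an amine substituent on a weakly soluble core

This account rests on a few compounds, and the source may have more. Where it says the series, first, only, none or still open, it means among the compounds named here.

Of the compounds shown here, three have been measured in a physicochemical assay (Homo sapiens) for solubility, with a stated time of 18 h, at pH 7.4; a lower number here means a less soluble compound, a higher number a more soluble compound. Compound 1, `CCN(CC)c1ccc(/C=C2/SC(Nc3ccccc3)=NC2=O)cc1`, gives 0.1 ug/mL in this assay. Compound 2, `CN1CCN(c2ccc(/C=C3/SC(Nc4ccccc4)=NC3=O)cc2)CC1`, gives 0.35 ug/mL. Compound 3, `CCN(CC)c1ccc(/C=C2/SC(N(C)c3ccccc3)=NC2=O)cc1`, gives 0.01 ug/mL, the lowest of the three numbers and well apart from both others. Compound 4, `CN1CCN(c2ccc(/C=C3/SC(N(C)c4ccccc4)=NC3=O)cc2)CC1`, has not yet been measured in this assay.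

Compound 2 is made from compound 1 by a single change, (4-methylpiperazin-1-yl in place of diethylamino on an aromatic carbon), and that change brought a 3.5-fold higher number from compound 1 to compound 2 (0.54 log units; beyond the scatter). Compound 3 stands apart from compound 1 in a different way, and that step in this assay was a 10-fold lower number from compound 1 to compound 3 (1.00 log units; beyond the scatter). The two cores involved differ as follows: methyl in place of hydrogen on a nitrogen on an aromatic ring.

Compound 4 is made from compound 3 by the same change that turns compound 1 into compound 2: 4-methylpiperazin-1-yl in place of diethylamino on an aromatic carbon. The descriptions of where the change sits agree word for word, so this is the same change, carried out on the second core rather than the first.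

From compound 3 to compound 4 in this assay a step of about a 3.5-fold higher number from compound 3 to compound 4 (0.54 log units; beyond the scatter) is expected. Going by the values given here, this expectation rests on the one earlier instance of the change, a 3.5-fold higher number from compound 1 to compound 2 (0.54 log units; beyond the scatter), and on nothing more, so the range around it is kept wide. A number this small may also come back from this assay only as a limit rather than a measured value. Compound 4 is therefore estimated at 0.035 ug/mL, with a likely span from 0.01 ug/mL to 0.12 ug/mL.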

Compound 4, solubility: 18.9 ug/mL
Beside the measured number, compound 4's estimate is 540-fold (2.73 log units) below it; the whole stated range lies below it.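

In this assay, putting 4-methylpiperazin-1-yl in place of diethylamino gave a 1900-fold higher number from compound 3 to compound 4 (3.28 log units; beyond the scatter) on the methylated core, whereas the same change had given a 3.5-fold higher number from compound 1 to compound 2 (0.54 log units; beyond the scatter) on the core of compound 1, so the direction carried over but the size did not. The methyl on the nitrogen tells the same story from the other side: it brought a 10-fold lower number from compound 1 to compound 3 (1.00 log units; beyond the scatter) when diethylamino was present, yet a 54-fold higher number from compound 2 to compound 4 (1.73 log units; beyond the scatter) when 4-methylpiperazin-1-yl was present, so the two changes do not simply add up in these four compounds and the effect of one depends on the other. This is a single pair of cores, so it does not show how the change would behave on any further core, and nothing measured here accounts for the difference between the two steps.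

On these data alone, it remains open whether the large step belongs to 4-methylpiperazin-1-yl in particular or would also appear with another amine on the same aromatic carbon, such as morpholin-4-yl or piperidin-1-yl. As far as these compounds go, it is also open whether a group other than methyl on that nitrogen, such as ethyl, would pair with 4-methylpiperazin-1-yl in the same way.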